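A Mirror-Image Change at One Ring Carbon

This account rests on a few compounds, and the source may have more. Where it says the series, first, only, none or still open, it means among the compounds named here.

Measured so far:
compound 1, `Nc1ncc(-c2ccc(C(=O)N3CC[C@H](O)C3)cc2)nc1-c1ccc(C(F)(F)F)cc1`: > 90%
compound 2, `Nc1ccc(-c2nc(-c3ccc(S(=O)(=O)C4CC4)cc3)cnc2N)cn1`: > 90%

Both compounds were tested in an ADME assay on microsomes from liver (Mus musculus) for metabolic stability, read by LC-MS, using NADPH, with a stated time of 30 min, tested at 0.1 uM, in the presence of a further agent that is not named here; on this read-out higher numbers stand for a more stable compound and lower numbers for a less stable compound. In this assay compound 1 gives > 90%, and this is a limit of the assay, not a number. In this assay compound 2 gives > 90%, likewise a limit. Compound 1 thus stands only at a limit: the limit of > 90% in this assay, at which 2 of the 2 values shown sit. Beyond that, the two values show only that neither compound was broken down far within the stated time, and no order between them can be read.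

The not-yet-measured compound 3, `Nc1ncc(-c2ccc(C(=O)N3CC[C@@H](O)C3)cc2)nc1-c1ccc(C(F)(F)F)cc1`, is related to compound 1 by a single change: the two compounds have the same atoms and bonds and differ only in configuration as drawn: 1 of 1 stereo elements differ; a stereocentre at a saturated ring carbon is drawn S in compound 1 and R in compound 3. Going by the values given here, no measured pair shows a change of this kind, so there is no step to lean on; the two compounds share every atom and bond and differ only in the configuration as drawn at one saturated ring carbon. The expected step in this assay is a step that the limit leaves unreadable from compound 1 to compound 3, none beyond the usual scatter. Compound 3 is accordingly estimated at 92%, with a range from 80% to 100%, and is expected most likely to be reported again only as a limit.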

Compound 3, percent of the compound remaining: > 90%
Compound 3: only a limit was reported; the forecaster's own chance of this, stated with the estimate: 80%; the middle value lies beyond the limit too.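

Compound 1 and compound 3 differ only in the configuration drawn at one saturated ring carbon, yet no step between them can be read, because all the results are limits of the assay and not numbers: the limit of > 90% in this assay, at which 3 of the 3 values shown sit.

The compounds shown leave open whether this mirror-image change makes any difference in this assay, and how the three compounds would order below that limit.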